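A few compounds are considered here, and "the series" means these few. Any claim that something is new, unique, unknown or untested is made for them only; others in the source may bear on it.

The measured compounds, in an ADME assay on L02 cells (Homo sapiens) for cytotoxicity, read by MTT assay, with a stated time of 48 h; on this read-out lower numbers stand for stronger inhibition and higher numbers for weaker inhibition:

Compound 1 `C#CCN1CCN(CC(=O)N2CCN(c3ccc(C(=O)c4cc5ccc(N(CC)CC)cc5o4)cc3)CC2)CC1`: in this assay compound 1 gives > 100000 nM, which is a limit of the assay rather than a number.
Compound 2 `CCOC(=O)CN1CCN(CC(=O)N2CCN(c3ccc(C(=O)c4cc5ccc(N(CC)CC)cc5o4)cc3)CC2)CC1`: in this assay compound 2 gives 68700 nM.

For the measured compounds named here, compound 2 holds the only number seen so far; the other value is a limit, as the limit of > 100000 nM in this assay, at which 1 of the 2 values shown sits, records. Going by the values given here, the single measured step, an at least 1.4-fold lower number from compound 1 to compound 2 (0.16 log units; that floor lies within the scatter), changes the group on the saturated chain carbon bound to the piperazine nitrogen, and its size cannot be fixed beyond the scatter.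

Compound 3 `CCN(CC)c1ccc2cc(C(=O)c3ccc(N4CCN(C(=O)CN5CCN(CC(C)=O)CC5)CC4)cc3)oc2c1` follows from compound 2 through (methyl in place of ethoxy on a carbonyl carbon), so the ester end of that same chain becomes a ketone. Among the compounds with values here, the only measured step touches this part of the molecule, and it shows no clear movement. The change from ethoxy to methyl on a carbonyl carbon is smaller than the earlier swap, and nothing measured points in either direction. A step of a 1.1-fold lower number from compound 2 to compound 3 (0.02 log units; within the scatter) is therefore expected, which is within the scatter. Compound 3 is estimated at 65000 nM, with a likely range from 25000 nM to 160000 nM.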

Compound 3, half-maximal inhibitory concentration: > 100000 nM
Compound 3: a limit, no number; the forecaster's own chance of this, stated with the estimate: 35%; middle value at least 1.5-fold (0.18 log units) away from the limit.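

In this assay compound 3 gives > 100000 nM, which is a limit of the assay and not a number. Exchanging ethoxy for methyl on a carbonyl carbon, the change from ethoxycarbonyl to acetyl, gives an at least 1.4-fold higher number from compound 2 to compound 3 (0.16 log units; that floor lies within the scatter), so this position has now been varied at its outer end as well, and the smallest step the data allow still cannot be told apart from ordinary scatter. Compound 1 and compound 3 carry different groups at the end of this chain yet share one limit, and the step between them cannot be read for that reason: the limit of > 100000 nM in this assay, at which 2 of the 3 values shown sit.

From the compounds shown here alone, how far compound 3 truly lies from compound 2 remains open, as does whether the ester of compound 2 differs at all from the acetyl group, since a limit gives no number to compare with. Also open, going by these compounds, is how this cytotoxicity read-out would respond to a carboxylic acid or an amine at the end of this chain, or to a longer chain carrying the same carbonyl group.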